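The source may hold more compounds than are shown below. What is called first, only, known or untested is meant among the compounds shown, and "the series" means these compounds.

Three compounds have so far been measured in an assay on microsomes from liver for inhibition of 3-hydroxy-3-methylglutaryl-coenzyme A reductase (Rattus norvegicus); a lower number here means a stronger inhibitor, a higher number a weaker inhibitor:

Compound 1, `CC(C)c1c(C(=O)N(C)Cc2ccccc2)nn(-c2ccc(F)cc2)c1OC[C@@H](O)C[C@@H](O)CC(=O)O`: 5.2 nM
Compound 2, `CC(C)c1c(C(=O)NCc2ccccn2)nn(-c2ccc(F)cc2)c1OC[C@@H](O)C[C@@H](O)CC(=O)O`: 25 nM
Compound 3, `COc1cccc(CNC(=O)c2nn(-c3ccc(F)cc3)c(OC[C@@H](O)C[C@@H](O)CC(=O)O)c2C(C)C)c1`: 16 nM

All three share one core and differ only in the group attached to the amide carbonyl. Compound 3 stands second highest of the three numbers. Its nearest neighbour is compound 2, and the step of a 1.6-fold lower number from compound 2 to compound 3 (0.19 log units; within the scatter) lies within the scatter, so the two cannot be told apart. Its furthest neighbour is compound 1, and the step of a 3.1-fold higher number from compound 1 to compound 3 (0.49 log units; beyond the scatter) is beyond the scatter, as is a 4.8-fold higher number from compound 1 to compound 2 (0.68 log units; beyond the scatter).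

Compound 4, `CC(C)c1c(C(=O)NCc2cccc(Cl)c2)nn(-c2ccc(F)cc2)c1OC[C@@H](O)C[C@@H](O)CC(=O)O`, keeps everything of compound 3 except one substituent: chloro in place of methoxy on an aromatic carbon. Among the compounds with values here, no measured step alters a substituent on the benzyl ring itself; the steps seen so far swap the whole group on the amide nitrogen. The closest comparison, the exchange of one aromatic ring for another from compound 2 to compound 3, stayed within the scatter. On that basis a change of similar or smaller size is expected in this assay , in no direction beyond the scatter, so the step of a 1.1-fold lower number from compound 3 to compound 4 (0.06 log units; within the scatter) is expected to be small. Compound 4 is therefore estimated at 14 nM, with a range from 6 nM to 35 nM.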

Compound 4, half-maximal inhibitory concentration: 5.4 nM
Beside the measured number, compound 4's estimate is 2.6-fold (0.41 log units) above it; the measured number lies below the stated range.
By their numbers in this assay, from the lowest: compounds 1 and 4 (each within the scatter of the next); then compounds 3 and 2 (each within the scatter of the next).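

In this assay, within the data shown here, this is the first change made on the benzyl ring itself, and it shows that a single substituent at this aromatic carbon can matter: chloro in place of methoxy, a swap of 2 heavy atoms for 1, gives a 3.0-fold lower number from compound 3 to compound 4 (0.47 log units; beyond the scatter) and lies beyond the scatter. The 3-chlorobenzyl amide also stands clearly apart from the amide carrying pyridin-2-yl, with a 4.6-fold lower number from compound 2 to compound 4 (0.67 log units; beyond the scatter) beyond the scatter, whereas a 1.0-fold higher number from compound 1 to compound 4 (0.02 log units; within the scatter) lies within it, so the (3-chlorobenzyl)amino and benzyl(methyl)amino groups cannot be told apart in this comparison. No evidence is available to explain why chloro and methoxy differ here.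

The compounds shown leave open how other groups on this aromatic carbon, such as fluoro, methyl or plain hydrogen, would compare, so it remains unclear whether chloro or methoxy is the more unusual of the two. They also leave open whether a methyl group on the amide nitrogen of compound 4, as carried by compound 1, would change the number further.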